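Trifluoromethyl in place of methoxy on the aromatic carbon

The source may report more compounds than this note shows. Statements on the series, on what has been measured and on what is new or still open speak of the compounds shown alone.

Compound 2 `COc1ccnc(N2CCC(NC(=S)Nc3cccnc3)CC2)c1` carries a methoxy group and, in an assay on membranes from brain for binding affinity to Lysophosphatidylserine lipase ABHD12 (Mus musculus), read by fluorescence, with a stated time of 20 min (a lower number here means a stronger inhibitor, a higher number a weaker inhibitor), gives only the limit of the assay, > 5000 nM. Compound 1 `S=C(Nc1cccnc1)NC1CCN(c2cc(Cl)ccn2)CC1`, which carries chloro at the same aromatic carbon, gives 2100 nM. Compound 3 `S=C(Nc1cccnc1)NC1CCN(c2ncccc2Cl)CC1` also reaches only the limit, > 5000 nM. Compound 4 `FC(F)(F)c1ccnc(N2CCC(NC(=S)Nc3cccnc3)CC2)c1` differs from compound 2 in one place: trifluoromethyl in place of methoxy on an aromatic carbon. Among the compounds with values here, the one measured step that touches this position runs the other way, an at least 2.3-fold higher number from compound 1 to compound 2 (0.37 log units; beyond the scatter), and the limit of > 5000 nM in this assay, at which 2 of the 3 values shown sit, leaves its true size open. Within the data shown here, no measured step carries a trifluoromethyl group, so the expectation for compound 4 rests on the chloro analogue alone and is loose. Compound 4 is expected near 3000 nM, between 1000 nM and 10000 nM. That estimate means an at least 1.6-fold lower number from compound 2 to compound 4 (0.22 log units; that floor lies within the scatter) is expected.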

Compound 4, half-maximal inhibitory concentration: 640 nM
The estimate for compound 4 lay 4.7-fold (0.67 log units) above the measured number, outside the stated range (below it).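

In this assay, the aromatic carbon opposite the ring nitrogen turns out to tolerate more than the chloro of compound 1 suggested, with trifluoromethyl giving a 3.3-fold lower number from compound 1 to compound 4 (0.52 log units; beyond the scatter). Against methoxy the change is larger, an at least 7.8-fold lower number from compound 2 to compound 4 (0.89 log units; beyond the scatter). The value of compound 2 is a limit, so this step has only a floor: the limit of > 5000 nM in this assay, at which 2 of the 4 values shown sit.

On these data alone, whether a nitrile or a methyl group at this carbon would match trifluoromethyl stays open. So does whether these steps carry over to any core other than the one shared by compound 1, compound 2 and compound 4.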